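The compounds below may be only part of what the source reports. "The series", "measured", "known", "first", "only" and "open" are said of these compounds alone.

Compound 1, `Cc1ccccc1NC(=O)Nc1cccc(CNc2ncnc3ccccc23)c1`: in a functional assay on A549 cells (Homo sapiens) for antiproliferative activity, read by MTT assay (on this read-out higher numbers stand for weaker inhibition and lower numbers for stronger inhibition), compound 1 gives 40200 nM.
Compound 2, `COc1ccccc1NC(=O)Nc1cccc(CNc2ncnc3ccccc23)c1`: compound 2 gives 30800 nM.
Compound 3, `COc1ccc(NC(=O)Nc2cccc(CNc3ncnc4ccccc34)c2)cc1`: compound 3 gives 29300 nM.

Compound 3 is the reference here. Its steps from the other two, a 1.4-fold lower number from compound 1 to compound 3 (0.14 log units; within the scatter) and a 1.1-fold lower number from compound 2 to compound 3 (0.02 log units; within the scatter), both fall within the scatter, as does a 1.3-fold lower number from compound 1 to compound 2 (0.12 log units; within the scatter), so on the numbers shown the three compounds cannot be told apart in this assay.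

Compound 4, `CC(C)(C)c1ccc(NC(=O)Nc2cccc(CNc3ncnc4ccccc34)c2)cc1`, has not yet been measured. It differs from compound 3 in one place: tert-butyl in place of methoxy on an aromatic carbon. Within the data shown here, the steps that bear on this are the two that alter the same aryl substituent, leading from compound 1 and from compound 2 to compound 3, and both were within the scatter. Among the measured compounds shown here, no measured compound carries a tert-butyl group at this place, so the expectation rests only on the three substituents tried so far leaving the number unchanged. Compound 4 is therefore expected to show a step of a 1.0-fold lower number from compound 3 to compound 4 (0.02 log units; within the scatter), that is, nothing beyond the scatter. The estimate for compound 4 is 28000 nM, with a range from 10000 nM to 80000 nM.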

Compound 4, half-maximal inhibitory concentration: 17900 nM
Compound 4: the middle estimate sits 1.6-fold (0.19 log units) above what was measured, and the stated range covers the measured number.
By their numbers in this assay, from the lowest: compounds 4, 3, 2 and 1 (each within the scatter of the next, the first and the last beyond it).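

In this assay, putting tert-butyl, with its 4 heavy atoms and no hydrogen-bond acceptor, in place of methoxy on the aromatic carbon para to a large group stays within the scatter: a 1.6-fold lower number from compound 3 to compound 4 (0.21 log units; within the scatter). Among these compounds, the change from the 2-methoxyphenyl compound also stays within it, at a 1.7-fold lower number from compound 2 to compound 4 (0.24 log units; within the scatter), but the change from the 2-methylphenyl compound gives the first step in this set to clear the scatter, a modest 2.2-fold lower number from compound 1 to compound 4 (0.35 log units; beyond the scatter). No measurement offered here accounts for that step.

The compounds shown leave open whether an amine, a carboxylic acid or a longer alkyl chain on this aromatic carbon would move the number further. They also leave open how tert-butyl would read at the other carbons of that ring.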